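A Second Methoxy on the Core of Compound 1

This account rests on a few compounds, and the source may have more. Where it says the series, first, only, none or still open, it means among the compounds named here.

For the measured compounds named here, in an in vitro ADME assay on microsomes (Rattus norvegicus) for metabolic stability (on this read-out lower numbers stand for a shorter-lived compound and higher numbers for a longer-lived compound), compound 1 (`CCC(CC)Nc1nc(OC)c(-c2ccc(Cl)cc2Cl)nc1C`) gives 0.283 h, the higher of the two numbers measured so far, while compound 2 (`CCC(CC)Nc1nc(C)c(-c2ccc(Cl)cc2Cl)nc1C`) gives 0.0533 h. Compound 3 (`CCC(CC)Nc1nc(OC)c(-c2ccc(Cl)cc2Cl)nc1OC`) has not yet been measured. It carries methoxy in place of methyl on an aromatic carbon, ortho to a (pentan-3-yl)amino group and para to a methoxy group: methoxy in place of methyl on an aromatic carbon. Going by the values given here, the only measured step that bears on this is a 5.3-fold lower number from compound 1 to compound 2 (0.73 log units; beyond the scatter), a modest change in which methyl replaced that other methoxy group. It shows a methoxy-to-methyl swap on the core, but at a different place, so its reverse is only a loose guide here. A small rise in this assay is therefore expected, with the estimated step being a 1.8-fold higher number from compound 1 to compound 3 (0.25 log units; within the scatter). Compound 3 is expected at 0.5 h, with an estimated range of 0.2 h to 1.3 h.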

Compound 3, half-life: 0.0417 h
Compound 3: the middle estimate sits 12-fold (1.08 log units) above what was measured; the whole stated range lies above it.
By their numbers in this assay, from the lowest: compounds 3 and 2 (each within the scatter of the next); then compound 1.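

Methoxy in place of methyl on the aromatic carbon ortho to a (pentan-3-yl)amino group gives a 6.8-fold lower number from compound 1 to compound 3 (0.83 log units; beyond the scatter) in this assay, so this position, like the other one, does not favour the change that was read across to it. Set beside a 5.3-fold lower number from compound 1 to compound 2 (0.73 log units; beyond the scatter), where methyl replaced the other methoxy group, this leaves compound 1, with one methoxy and one methyl on the core, above both of its single-change neighbours; methoxy therefore goes with opposite directions of change at the two places. Nothing measured here accounts for this drop in half-life.

On these data alone, only methyl and methoxy have been seen at this position, and how an ethyl group, a chlorine atom or an amine would fare there remains open. Also open, as far as these compounds go, is whether the same step would appear with a smaller amine, such as cyclopropylamino, in place of the (pentan-3-yl)amino group.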